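The compounds below may be only part of what the source reports. "The series", "measured", "known", "first", "only" and "open" are said of these compounds alone.

Working notes on the series, all values from a functional assay on MCF7 cells (Homo sapiens) for antiproliferative activity, read by MTT assay, with a stated time of 72 h; a higher number here means a weaker inhibitor, a lower number a stronger inhibitor.

Compound 1, `O=C(Nc1ccc(Cl)c(-c2nnc3c(Cl)cccn23)c1)c1ccccc1`: > 100000 nM, a limit of the assay.
Compound 2, `O=C(Nc1ccc(Cl)c(-c2nnc3c(Cl)cccn23)c1)c1c(F)cccc1Cl`: > 100000 nM, a limit of the assay.
Compound 3, `CS(=O)(=O)c1cccc(C(=O)Nc2ccc(Cl)c(-c3nnc4c(Cl)cccn34)c2)c1`: 88900 nM.

Compound 2 stands at the limit of this assay, the position it shares with compound 1 as recorded in the limit of > 100000 nM in this assay, at which 2 of the 3 values shown sit. Only compound 3 gives a number, so the step of an at least 1.1-fold lower number from compound 2 to compound 3 (0.05 log units; that floor lies within the scatter) can be read only as a floor that itself lies within the scatter, and the step that the two limits leave unreadable from compound 1 to compound 2 cannot be sized at all. Compound 2 is therefore placed no more precisely than at the weak end of what this assay can report.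

Compound 4, `O=C(Nc1ccc(Cl)c(-c2nnc3c(Cl)cccn23)c1)c1cccnc1Cl`, differs from compound 2 in one place: 2-chloropyridin-3-yl in place of 2-chloro-6-fluorophenyl on a carbonyl carbon. The measured steps that bear on a change at the carbonyl carbon are a step that the two limits leave unreadable from compound 1 to compound 2 and an at least 1.1-fold lower number from compound 2 to compound 3 (0.05 log units; that floor lies within the scatter), and neither shows a movement beyond the scatter. The step expected from this change, a number no higher from compound 2 to compound 4 (the limit leaves the size open), is accordingly none beyond the scatter. Compound 4 is estimated at 100000 nM in this assay. The expected range for compound 4 runs from 40000 nM to 250000 nM, with a fair chance that only a limit is reported.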

Compound 4, half-maximal inhibitory concentration: > 100000 nM
Compound 4: no number, only a limit; the forecaster's own chance of this, stated with the estimate: 65%; the middle value lies on the limit itself.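

Placing the 2-chloropyridin-3-yl group, with its ring hetero atom and hydrogen-bond acceptor, on the carbonyl carbon does not lift compound 4 off the weak end of this assay, so a third group at this position joins the two already there: the limit of > 100000 nM in this assay, at which 3 of the 4 values shown sit.

The steps from compound 2 to compound 4 and from compound 1 to compound 4 have limits at both ends and cannot be read. For the compounds shown here, the one step that can be read, an at least 1.1-fold higher number from compound 3 to compound 4 (0.05 log units; that floor lies within the scatter), is only a floor inside the scatter, so compound 3, the one compound with a number, is still not separated from compound 4.

As far as these compounds go, it remains open whether any group on this carbonyl carbon brings a compound clearly inside the measurable range of this assay, for instance a phenyl ring carrying an amine or a carboxylic acid, or a longer alkyl chain in place of the ring. With only one number in hand, the compounds shown also cannot tell whether the shared core itself holds the series at this limit, whatever stands on the carbonyl carbon.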